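Sulfation of the hydroxyl: alkyl glycoside series

This account rests on a few compounds, and the source may have more. Where it says the series, first, only, none or still open, it means among the compounds named here.

Three compounds have numbers in a functional assay on A-375 cells (Homo sapiens), read by thymidine incorporation; on this read-out higher numbers stand for weaker inhibition and lower numbers for stronger inhibition. Compound 1 `CCCCCCCC/C=C\CCCCCCCCO[C@H]1O[C@H](CO)[C@@H](O)[C@H](O)[C@H]1NC(C)=O` gives 4.8 uM. Compound 2 `CCCCCCCCCCCCCCCCO[C@H]1O[C@H](COCC(CO)(CO)COS(=O)(=O)O)[C@@H](O)[C@H](O)[C@H]1NC(=O)CCCC` gives 2.3 uM, and compound 3 `CCCCCCCCCCCCCCCCO[C@H]1O[C@H](COCC(CO)(CO)CO)[C@@H](O)[C@H](O)[C@H]1NC(=O)CCCC` gives 17 uM. Within these three, compound 1 stands second highest; its number lies beyond the scatter from both compound 2 and compound 3.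

Within the data shown here, the one matched pair in the set is compound 3 to compound 2, differing by sulfo in place of hydrogen on an oxygen on a saturated carbon. That change made a 7.4-fold lower number from compound 3 to compound 2 (0.87 log units; beyond the scatter), a clear drop in the number and so stronger inhibition.

Compound 4 `CCCCCCCC/C=C\CCCCCCCCO[C@H]1O[C@H](CO)[C@@H](O)[C@H](OS(=O)(=O)O)[C@H]1NC(C)=O` is not yet measured. It differs from compound 1 by sulfo in place of hydrogen on an oxygen on a saturated carbon. This is the same kind of change as that from compound 3 to compound 2, but not the same: there the oxygen sits on a saturated carbon whose other neighbours are saturated chain carbon, whereas in compound 4 the oxygen sits on a saturated carbon whose other neighbours are saturated ring carbon. How the core of compound 1 differs from the core of compound 3 is not broken down here.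

The expectation for compound 4 rests on one pair only, and the placement of the sulfo group differs, so the step is expected to be somewhat smaller than a 7.4-fold lower number from compound 3 to compound 2 (0.87 log units; beyond the scatter). The step from compound 1 to compound 4 is estimated as a 4.8-fold lower number from compound 1 to compound 4 (0.68 log units; beyond the scatter). Compound 4 is expected to give about 1 uM, with a range from 0.3 uM to 3.5 uM.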

Compound 4, concentration for 50% inhibition: 2.1 uM
Compound 4: the middle estimate sits 2.1-fold (0.32 log units) below what was measured; measured number inside the range.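

In this assay, sulfo in place of hydrogen on an oxygen on a saturated carbon again lowers the number, with a 2.3-fold lower number from compound 1 to compound 4 (0.36 log units; beyond the scatter), so the direction of the step holds on the core of compound 1 as it does on the core of compound 3. The size of the step does not carry over unchanged: the same change on two cores in this assay, a 7.4-fold lower number (0.87 log units; beyond the scatter) from compound 3 to compound 2 and a 2.3-fold lower number (0.36 log units; beyond the scatter) from compound 1 to compound 4, 3.2-fold (0.51 log units) apart, beyond the scatter of two such steps. This does not show what sets the size, since the two pairs differ both in the core and in the place of the change, with the oxygen on a saturated carbon whose other neighbours are saturated chain carbon in one pair and saturated ring carbon in the other, and two steps cannot separate these, nor can they predict the step on any further core.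

The compounds shown leave open how the step would change if the sulfo group stood on another hydroxy group of the core of compound 1, which would test the place of the change on a single core. They also leave open whether a phosphate or a carboxylic acid in place of the sulfooxy group would lower the number in the same way, and whether a longer chain would alter the step.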